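The source may report more compounds than this note shows. Statements on the series, on what has been measured and on what is new or still open speak of the compounds shown alone.

Measured so far:
- compound 1 `O=C(/C=C/c1ccc2c(c1)B(O)OC2)c1cccs1` — 26000 nM
- compound 2 `Cn1cccc1C(=O)/C=C/c1ccc2c(c1)B(O)OC2` — > 100000 nM, a limit of the assay
- compound 3 `O=C(/C=C/c1ccc2c(c1)B(O)OC2)c1cccc(F)c1` — 26700 nM

In a toxicity assay on WI-38 cells (Homo sapiens) for cytotoxicity, read by MTT assay, with a stated time of 48 h (on this read-out lower numbers stand for stronger inhibition and higher numbers for weaker inhibition), compound 1 gives 26000 nM, and compound 3 sits close to it, the pair lying within scatter a 1.0-fold higher number from compound 1 to compound 3 (0.01 log units; within the scatter). Compound 2 reaches only a limit in this assay (the limit of > 100000 nM in this assay, at which 1 of the 3 values shown sits). The next analogue, compound 4 `Cc1cccc(C(=O)/C=C/c2ccc3c(c2)B(O)OC3)c1`, carries 3-methylphenyl in place of thiophen-2-yl on a carbonyl carbon. Of the measured steps, the one to the other six-membered carbon ring stayed within scatter a 1.0-fold higher number from compound 1 to compound 3 (0.01 log units; within the scatter), whereas the five-membered ring change moved far an at least 3.8-fold higher number from compound 1 to compound 2 (0.58 log units; beyond the scatter). Compound 4 is the aryl case, so the expected step is small, a 1.1-fold higher number from compound 1 to compound 4 (0.03 log units; within the scatter), with no change beyond the scatter. The estimate for compound 4 is 28000 nM, with a range from 12000 nM to 65000 nM.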

Compound 4, half-maximal inhibitory concentration: 16700 nM
Compound 4: the middle estimate sits 1.7-fold (0.22 log units) above what was measured; the measured number falls inside the stated range.
By their numbers in this assay, from the lowest: compounds 4, 1 and 3 (each within the scatter of the next). At a limit, above all of these: compound 2.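

With 3-methylphenyl on the carbonyl carbon, the number stays within the scatter of both thiophen-2-yl (a 1.6-fold lower number from compound 1 to compound 4 (0.19 log units; within the scatter)) and 3-fluorophenyl, so methyl in place of fluoro on an aromatic carbon is also a small step (a 1.6-fold lower number from compound 3 to compound 4 (0.20 log units; within the scatter)). Among these compounds, the only step beyond the scatter among the new ones is the one away from 1-methyl-1H-pyrrol-2-yl (an at least 5.9-fold lower number from compound 2 to compound 4 (0.77 log units; beyond the scatter)). Compound 2 still gives a limit and not a number: the limit of > 100000 nM in this assay, at which 1 of the 4 values shown sits.

The compounds shown leave open whether an amine or a carboxylic acid in place of that methyl would move the number beyond the scatter. Going by these compounds, the true size of the gap to compound 2 also stays open.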